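Swapping the sulfur-bound group on a naphthol amide core

The source may report more compounds than this note shows. Statements on the series, on what has been measured and on what is new or still open speak of the compounds shown alone.

Of the compounds shown here, two of a shared core have been measured in an assay on isolated protein for inhibition of RAC-alpha serine/threonine-protein kinase (Homo sapiens), read by fluorescence, with a stated time of 30 min, tested at 10 uM; on this read-out lower numbers stand for less inhibition and higher numbers for more inhibition at the one concentration tested (going by the name of the read-out). Compound 1 `O=C(Nc1cc(Sc2ncnc3nc[nH]c23)c(O)c2ccccc12)c1ccc(Cl)cc1` gives 21.7% in this assay. For the measured compounds named here, compound 2 `COc1ccc(/C=C/C(=O)Nc2cc(Sc3ncn[nH]3)c(O)c3ccccc23)cc1OC` gives 31.7% in this assay, and the two numbers lie within the usual scatter of each other, so compound 1 stands level with the only other measured compound rather than apart from it.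

Compound 3 `Cn1nnnc1Sc1cc(NC(=O)c2ccc(Cl)cc2)c2ccccc2c1O` has not been measured. It differs from compound 1 on a sulfur whose other neighbours are aromatic carbon: a group of 6 heavy atoms (2 carbon, 4 nitrogen; one five-membered aromatic ring with 4 hetero atoms) in place of a group of 9 heavy atoms (5 carbon, 4 nitrogen; one five-membered aromatic ring with 2 hetero atoms, one six-membered aromatic ring with 2 hetero atoms), on a sulfur. The entering 1-methyl-1H-tetrazol-5-yl brings no hydrogen-bond donor where the leaving group had one.

No comparable change between measured compounds exists here, so the step from compound 1 to compound 3 in this assay is expected to be small and within the scatter, with no direction established, as a number 3.7 percentage points lower from compound 1 to compound 3 (within the scatter). Compound 3 is therefore estimated to give about 18% in this assay, in a range from 0% to 40%.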

Compound 3, a percentage reported as inhibition, at one concentration (the size of the read-out at that concentration, not a potency): 13.1%
For compound 3 the middle estimate is 4.9 percentage points above the measured one; measured number inside the range.
By their numbers in this assay, from the lowest: compounds 3, 1 and 2 (each within the scatter of the next, the first and the last beyond it).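

With 1-methyl-1H-tetrazol-5-yl in place of the two-ring group of compound 1, the sulfur of the shared core gains its first direct comparison in this assay, which reads a number 8.6 percentage points lower from compound 1 to compound 3 (within the scatter) on this single change. Thus, replacing a group of 9 heavy atoms and 1 hydrogen-bond donor with one of 6 heavy atoms and 0 hydrogen-bond donors does not separate the two compounds beyond the scatter on this read-out. No supporting measurement bears on this result.

The compounds shown leave open whether a simple methyl, an amine or a short chain ending in a carboxylic acid on the sulfur would give a number beyond the scatter of compound 1. They also leave open how 1-methyl-1H-tetrazol-5-yl would read with the amide carried by compound 2.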